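The compounds below may be only part of what the source reports. "The series", "measured", "known", "first", "only" and "open" are said of these compounds alone.

Three compounds share a core in which two chains sit on a urea nitrogen, one of them ending in a sulfur that carries a ring system. Compound 1 `CCCCCCN(CCCCCSc1nc2ccccc2o1)C(=O)Nc1ccc(F)cc1F` gives 3500 nM in an assay on cells (Macrophage) for inhibition of sterol O-acyltransferase 1 (Mus musculus); a lower number here means a stronger inhibitor, a higher number a weaker inhibitor. Compound 2 `CCCCCCN(CCCCCSc1nc2c([nH]1)CCCC2)C(=O)Nc1ccc(F)cc1F` gives 2580 nM in this assay, and the step of a 1.4-fold lower number from compound 1 to compound 2 (0.13 log units; within the scatter). Compound 3 `CCCCCCCN(CCCCCSc1nc(O)c2ccccc2n1)C(=O)Nc1ccc(F)cc1F` gives 11000 nM in this assay, the highest of the three numbers, beyond the scatter from both others. Compound 4 `CCCCCCCN(CCCCCSc1[nH]cnc2ncnc1-2)C(=O)Nc1ccc(F)cc1F` differs from compound 3 by a group of 9 heavy atoms (5 carbon, 4 nitrogen; one five-membered aromatic ring with 2 hetero atoms, one six-membered aromatic ring with 2 hetero atoms) in place of a group of 11 heavy atoms (8 carbon, 2 nitrogen, 1 oxygen; one six-membered aromatic ring of carbon only, one six-membered aromatic ring with 2 hetero atoms), on a sulfur. Among the compounds with values here, the only measured step at this sulfur is the ring exchange from compound 1 to compound 2, which stayed within the scatter, so guidance is thin; a modest move toward the lower numbers of compound 1 and compound 2 seems plausible. The expected step is a 2.2-fold lower number from compound 3 to compound 4 (0.34 log units; beyond the scatter). For compound 4 the estimate is 5000 nM, with a range from 1500 nM to 15000 nM.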

Compound 4, half-maximal inhibitory concentration: 5320 nM
Compound 4: the middle estimate sits 1.1-fold (0.03 log units) below what was measured; low and high end bracket the measured number.
By their numbers in this assay, from the lowest: compounds 2, 1 and 4 (each within the scatter of the next, the first and the last beyond it); then compound 3.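

In this assay, replacing the 4-hydroxyquinazolin-2-yl group on the sulfur gives a 2.1-fold lower number from compound 3 to compound 4 (0.32 log units; beyond the scatter). Within the data shown here, this is the first step at this sulfur that lies beyond the scatter, so the group held there can shift the number, though only modestly here. The two groups match in hydrogen-bond donors, acceptors and net charge, so those counts do not separate them, and no measurement at hand explains the step. From the compounds shown here alone, how a single ring, such as plain phenyl, or a carboxylic acid on the sulfur would compare remains open.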